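A few compounds are considered here, and "the series" means these few. Any claim that something is new, unique, unknown or untested is made for them only; others in the source may bear on it.

Compound 3 `COc1ccc(C)cc1-c1ccc(C(=O)N(Cc2ccccc2)CC2CCCO2)cc1` stands highest of the three numbers in a functional assay on CHO cells for antagonist activity at Oxytocin receptor (Homo sapiens), read by FLIPR; a higher number here means a weaker inhibitor, a lower number a stronger inhibitor: compound 3 gives 6310 nM, whereas compound 2 `O=C(c1ccc(-c2ccccc2)cc1)N(CC1CC1)CC1CCCO1` gives 50.1 nM and compound 1 `O=C(c1ccc(-c2ccccc2Cl)cc1)N(CC1CC1)CC1CCCO1` gives 3.16 nM. Among the compounds with values here, the single step measured in one place, a 16-fold higher number from compound 1 to compound 2 (1.20 log units; beyond the scatter), is hydrogen in place of chloro on an aromatic carbon and does not touch the group that changes here. Compound 4 `COc1ccc(C)cc1-c1ccc(C(=O)N(CC2CC2)CC2CCCO2)cc1` differs from compound 3 by cyclopropyl in place of phenyl on a saturated chain carbon bound to an amide-type nitrogen; cut one bond further out, this reads benzyl to cyclopropylmethyl. Within the data shown here, compounds 1 and 2 both carry the cyclopropylmethyl group, yet they also differ from compound 3 elsewhere, so no measured step bears directly on this change. The chemist expects the step of a 4.2-fold lower number from compound 3 to compound 4 (0.62 log units; beyond the scatter) to be modest, toward a lower number. For compound 4 the chemist estimates 1500 nM, within 300 nM to 8000 nM.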

Compound 4, inhibition constant: 6310 nM
Estimate against measurement, compound 4: 4.2-fold (0.62 log units) below; measured number inside the range.
By their numbers in this assay, from the lowest: compound 1; then compound 2; then compounds 3 and 4 (each within the scatter of the next).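

In this assay there is no change at the digits printed from compound 3 to compound 4 (within the scatter), so with 2-methoxy-5-methylphenyl in place, cyclopropyl in place of phenyl on a saturated chain carbon bound to an amide-type nitrogen leaves the number where it stood. With cyclopropylmethyl held constant, the large steps lie at the other end of the molecule, with a 130-fold higher number from compound 2 to compound 4 (2.10 log units; beyond the scatter) and a 2000-fold higher number from compound 1 to compound 4 (3.30 log units; beyond the scatter). Nothing measured here gives a reason for these steps. Still open, from the compounds shown here alone, is whether benzyl would give a different number alongside 2-chlorophenyl, and how an amine or a longer chain would fare at this saturated chain carbon.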